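The compounds below may be only part of what the source reports. "The series", "measured", "known", "first", "only" and "open" are said of these compounds alone.

Among the measured compounds shown here, in a functional assay on A549 cells (Homo sapiens) for cytotoxicity, read by sulforhodamine B assay, with a stated time of 48 h, tested at 0.1 uM (on this read-out higher numbers stand for a weaker effect at the one concentration tested and lower numbers for a stronger effect), compound 1 `COc1ccc(C(=O)/C=C/c2cc(-c3cc(OC)c(OC)c(OC)c3)n[nH]2)cc1OC` gives 98%, which stands lowest of the two numbers so far, though only by a gap within the scatter. Its nearest neighbour, compound 2 `COc1ccc(C(=O)/C=C/c2cc(-c3cc(OC)c(OC)c(OC)c3)n[nH]2)cc1`, gives 101% in this assay. For the measured compounds named here, the single measured step, a number 3 percentage points higher from compound 1 to compound 2 (within the scatter), put hydrogen in place of methoxy on an aromatic carbon. Compound 3 `COc1cc(C(=O)/C=C/c2cc(-c3cc(OC)c(OC)c(OC)c3)n[nH]2)cc(OC)c1OC` goes the other way: methoxy in place of hydrogen on an aromatic carbon. Because that one comparable step was a number 3 percentage points higher from compound 1 to compound 2 (within the scatter), no shift beyond the scatter is expected. Compound 3 is therefore estimated at 98%, between 88% and 105%, an expected step of no change at the digits printed from compound 1 to compound 3 (within the scatter).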

Compound 3, a percentage reported as activity, at one concentration (the size of the read-out at that concentration, not a potency): 94%
Compound 3: the middle estimate sits 4 percentage points above what was measured; the measured number falls inside the stated range.
By their numbers in this assay, from the lowest: compounds 3, 1 and 2 (each within the scatter of the next).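

Methoxy in place of hydrogen at this position, ortho to a methoxy group and meta to a large group, gives a number 4 percentage points lower from compound 1 to compound 3 (within the scatter) in this assay. So on this ring, adding a methoxy group, like the earlier swap of one for hydrogen, a number 3 percentage points higher from compound 1 to compound 2 (within the scatter), produces no shift beyond the scatter. No measurement is available that would offer an explanation for these results.

As far as these compounds go, whether an amine or a carboxylic acid at this position would move the number beyond the scatter stays open. So does how these compounds behave at higher concentrations.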